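The compounds below may be only part of what the source reports. "The series", "measured", "known", "first", "only" and "open" are said of these compounds alone.

The measured compounds and their values:

compound 1, `CN(C)CCNc1ccnc2cc(OCc3ccc(F)cc3)ccc12`: 780 nM
compound 2, `CN(C)CCNc1ccnc2cc(OCc3ccccc3)ccc12`: 1620 nM
compound 3, `C=CCOc1ccc2c(NCCN(C)C)ccnc2c1`: 930 nM

In a functional assay on NCI-H1650 cells (Homo sapiens) for cytotoxicity, read by MTT assay, with a stated time of 48 h (a higher number here means a weaker inhibitor, a lower number a stronger inhibitor), compound 1 gives the lowest of the three numbers. Compound 3 lies nearest to it, and compound 2 furthest. The step of a 2.1-fold higher number from compound 1 to compound 2 (0.32 log units; beyond the scatter) is beyond the scatter, whereas the steps of a 1.2-fold higher number from compound 1 to compound 3 (0.08 log units; within the scatter) and a 1.7-fold lower number from compound 2 to compound 3 (0.24 log units; within the scatter) both stay within it. All three of these changes sit on the group attached through the oxygen on the aromatic ring; the chain carrying the dimethylamino group is the same in compounds 1, 2 and 3.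

Compound 4, `CN(C)CCCNc1ccnc2cc(OCc3ccc(F)cc3)ccc12`, differs from compound 1 at that chain instead: (dimethylamino)methyl in place of dimethylamino on a saturated chain carbon, two bonds along the chain from a nitrogen on an aromatic ring. For the measured compounds named here, none of the measured steps touches this part of the molecule, so no measured step bears directly on the change, and there is no basis in these data for expecting a shift in either direction. As far as these compounds go, the reasonable expectation is therefore no step beyond the scatter in this assay, with the range widened because the change is untested. Compound 4 is expected to give about 900 nM, between 350 nM and 2500 nM. The expected step is a 1.2-fold higher number from compound 1 to compound 4 (0.06 log units; within the scatter), which is within the scatter.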

Compound 4, half-maximal inhibitory concentration: 940 nM
For compound 4 the middle estimate is 1.0-fold (0.02 log units) below the measured one, and the stated range covers the measured number.
By their numbers in this assay, from the lowest: compounds 1, 3, 4 and 2 (each within the scatter of the next, the first and the last beyond it).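

In this assay, the change from the (2-(dimethylamino)ethyl)amino chain to the (3-(dimethylamino)propyl)amino chain gives a 1.2-fold higher number from compound 1 to compound 4 (0.08 log units; within the scatter) and so stays within the scatter. The earlier compounds shown here differed only in the group attached through the oxygen, so they could say nothing about this chain; this pair shows that, with the 4-fluorophenyl group kept in place, 3-(dimethylamino)propyl can stand where 2-(dimethylamino)ethyl stands without a step beyond the scatter in this cell assay. For the compounds shown here, nothing in the information available accounts for this result, and the single pair gives no explanation of it.

The compounds shown leave open whether a longer chain, such as 4-(dimethylamino)butyl, would also stay within the scatter, and whether the dimethylamino group itself could give way to a primary amine, a morpholine or a carboxylic acid at the end of the chain. They also leave open whether the same chain change would behave alike when the group attached through the oxygen is the phenyl of compound 2 or the vinyl of compound 3.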